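A few compounds are considered here, and "the series" means these few. Any claim that something is new, unique, unknown or untested is made for them only; others in the source may bear on it.

Measured so far in an ADME assay on H9c2 cells (Rattus norvegicus) for cytotoxicity, read by MTT assay, with a stated time of 48 h; on this read-out lower numbers stand for stronger inhibition and higher numbers for weaker inhibition:
- compound 1 `O=C(NCCOC(=S)Nc1ccc(F)cc1)c1cccnc1`: > 800000 nM (a limit)
- compound 2 `Cc1cnc(C(=O)Oc2ccc(C(N)=S)cc2)c[n+]1[O-]`: 780000 nM
- compound 3 `O=C(NCCOC(=S)Nc1ccccc1)c1cccnc1`: > 800000 nM (a limit)

Compound 3 has only a limit, > 800000 nM, and no number. The series clusters at the limit of > 800000 nM in this assay, at which 2 of the 3 values shown sit.

Compound 4 `COc1ccc(NC(=S)OCCNC(=O)c2cccnc2)cc1` differs from compound 3 by methoxy in place of hydrogen on an aromatic carbon, para to a large group: methoxy in place of hydrogen on an aromatic carbon. Going by the values given here, the one measured step bearing on this is a step that the two limits leave unreadable from compound 1 to compound 3, hydrogen in place of fluoro on an aromatic carbon. It offers no size to carry over, so no step beyond the scatter is expected in this assay, in either direction. The expected change is a number no higher from compound 3 to compound 4 (the limit leaves the size open). For compound 4 the estimate is 800000 nM, with an expected range from 400000 nM to 1300000 nM.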

Compound 4, half-maximal inhibitory concentration: 695000 nM
For compound 4 the middle estimate is 1.2-fold (0.06 log units) above the measured one; the measured number falls inside the stated range.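

In this assay, methoxy on an aromatic carbon, para to a large group, gives compound 4 a measured number rather than a limit, at 695000 nM. In place of hydrogen the change gives an at least 1.1-fold lower number from compound 3 to compound 4 (0.06 log units; that floor lies within the scatter), and in place of fluoro it gives an at least 1.1-fold lower number from compound 1 to compound 4 (0.06 log units; that floor lies within the scatter). Neither step is shown to exceed the scatter, and their full size cannot be read from the limits: the limit of > 800000 nM in this assay, at which 2 of the 4 values shown sit.

Still open, going by these compounds, is whether an amine or a carboxylic acid at this place would move the number beyond the scatter. A longer chain in place of methoxy is equally untested among the compounds shown.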